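A Nitrile Phenyl in Place of a Pyridine Ring

This account rests on a few compounds, and the source may have more. Where it says the series, first, only, none or still open, it means among the compounds named here.

Compound 1 `CC1(C)Cc2c(-c3ccncc3)c(-c3ccccn3)nn2C1` is the starting point. In a functional assay on MCF7 cells (Homo sapiens) for cytotoxicity, with a stated time of 72 h (on this read-out higher numbers stand for weaker inhibition and lower numbers for stronger inhibition), compound 1 gives > 100000 nM, which is a limit of the assay rather than a number. Compound 1 therefore sits at the limit of > 100000 nM in this assay, at which 2 of the 3 values shown sit. Compound 3 `Cc1cccc(-c2nn3c(c2-c2ccncc2)C(C)C(C)(C)C3)n1` is a close relative; in this assay compound 3 gives > 100000 nM, again a limit and not a number. Compound 2 `CCc1cccc(-c2nn3c(c2-c2ccnc(Nc4ccc(S(N)(=O)=O)cc4)c2)C(C)C(C)(C)C3)n1`, which carries a much larger added group, is the only one of the three to give a number: in this assay compound 2 gives 28000 nM.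

Compound 4 `CC1(C)Cc2c(-c3ccncc3)c(-c3ccccc3C#N)nn2C1` has not yet been tested. It differs from compound 1 in one place: 2-cyanophenyl in place of pyridin-2-yl on an aromatic carbon. For the measured compounds named here, no measured pair shows the effect of exchanging these two groups, so the step from compound 1 to compound 4 cannot be read from the data, and with compound 1 itself at a limit, any step is expected to be small, not beyond the scatter. Compound 4 is therefore expected to give about 100000 nM in this assay, between 30000 nM and 300000 nM, with a good chance that only a limit is reported again. The expected step of a number no higher from compound 1 to compound 4 (the limit leaves the size open) is essentially none.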

Compound 4, half-maximal inhibitory concentration: > 100000 nM
Compound 4: only a limit was reported (the forecaster's own chance of this, stated with the estimate: 70%); the middle value sits exactly at the limit.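

In this assay, for the compounds shown here, compound 1 and compound 4 each give only a limit and not a number, so no step between them can be read: the limit of > 100000 nM in this assay, at which 3 of the 4 values shown sit.

From the compounds shown here alone, whether 2-cyanophenyl in place of pyridin-2-yl changes the cytotoxicity of the shared core at all, and by how much, stays open.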